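Notes on replacing acetamido on the saturated ring

The source may report more compounds than this note shows. Statements on the series, on what has been measured and on what is new or still open speak of the compounds shown alone.

Measured so far in an ADME assay on cells (Hepatocyte, Homo sapiens) for metabolic stability; on this read-out lower numbers stand for a shorter-lived compound and higher numbers for a longer-lived compound:
- Compound 1 `CS(=O)(=O)NC1CCC(CN2CCN(c3cc(=O)c4cc(C(F)(F)F)cc([N+](=O)[O-])c4s3)CC2)CC1` gives > 1.55 h (a limit)
- Compound 2 `CC(=O)OC1CCC(CN2CCN(c3cc(=O)c4cc(C(F)(F)F)cc([N+](=O)[O-])c4s3)CC2)CC1` gives < 0.15 h (a limit)
- Compound 3 `CC(=O)NC1CCC(CN2CCN(c3cc(=O)c4cc(C(F)(F)F)cc([N+](=O)[O-])c4s3)CC2)CC1` gives > 1.55 h (a limit)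

Compound 3 stands at > 1.55 h, which is a limit of this assay and not a number. Compound 1 sits at the same limit, and the comparison leaves a step that the two limits leave unreadable from compound 1 to compound 3.

In compound 4 `COc1ccc(C(=O)OC2CCC(CN3CCN(c4cc(=O)c5cc(C(F)(F)F)cc([N+](=O)[O-])c5s4)CC3)CC2)cc1`, ((4-methoxyphenyl)carbonyl)oxy comes in place of acetamido on a saturated ring carbon (((4-methoxyphenyl)carbonyl)oxy in place of acetamido on a saturated ring carbon). Among the compounds with values here, the entering group is joined through a carbonyloxy link, as is the acetoxy of compound 2, the only compound of that kind measured so far. The closest evidence is an at least 10-fold higher number from compound 2 to compound 3 (1.01 log units; beyond the scatter), where acetamido replaces acetoxy. The change from methanesulfonamido to acetoxy points the same way, with an at least 10-fold lower number from compound 1 to compound 2 (1.01 log units; beyond the scatter). Within the data shown here, neither step carries an aromatic ring in the entering group, so that part of the change has no measured precedent, and the estimate is kept wide on its upper side.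

A large fall is therefore expected, in the direction of a shorter-lived compound, and the expected change is an at least 7.7-fold lower number from compound 3 to compound 4 (0.88 log units; beyond the scatter). For compound 4 the estimated value is 0.2 h, with an expected range from 0.07 h to 0.7 h.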

Compound 4, half-life: 0.165 h
Compound 4: middle estimate off by 1.2-fold (0.08 log units), on the high side, within the range that was stated.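

In this assay compound 4 gives 0.165 h, the first figure in the series that is a number and not a limit, so the low end of this position can now be read as a value. On the saturated ring carbon, ((4-methoxyphenyl)carbonyl)oxy gives an at least 9.3-fold lower number from compound 3 to compound 4 (0.97 log units; beyond the scatter) and an at least 9.3-fold lower number from compound 1 to compound 4 (0.97 log units; beyond the scatter), so a second carbonyloxy-linked group falls short of both nitrogen-linked groups, and none of the four compounds goes against this. Against the acetoxy of compound 2, 4-methoxyphenyl in place of methyl on a carbonyl carbon gives an at least 1.1-fold higher number from compound 2 to compound 4 (0.04 log units; that floor lies within the scatter), so the aromatic ring shows no readable gain, though the true step may be larger, as compound 2 stands at a limit: the limit of < 0.15 h in this assay, at which 1 of the 4 values shown sits.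

Going by these compounds, the full size of the two falls stays open, because compound 1 and compound 3 stand at a limit: the limit of > 1.55 h in this assay, at which 2 of the 4 values shown sit. Also open is how a 4-methoxybenzamido group on the same saturated ring carbon would read, which would separate the carbonyloxy link from the 4-methoxyphenyl part.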